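Working notes: changing the sulfonyl aryl group of compound 3

The compounds below may be only part of what the source reports. "The series", "measured", "known", "first", "only" and "open" are said of these compounds alone.

In a functional assay on HCT-116 cells (Homo sapiens) for antiproliferative activity, read by MTT assay, with a stated time of 48 h (a lower number here means a stronger inhibitor, a higher number a weaker inhibitor), compound 3 (`COc1ncc(-c2ccc3nc(NC(C)=O)nn3c2)cc1NS(=O)(=O)c1ccc(Cl)cc1`) gives 740 nM and stands lowest of the three measured numbers, against compound 2 (`CC(=O)Nc1nc2ccc(-c3cnc(Cl)c(NS(=O)(=O)c4ccc(C)cc4)c3)cn2n1`) at 2650 nM and compound 1 (`CC(=O)Nc1nc2ccc(-c3cnc(Cl)c(NS(=O)(=O)c4ccc(F)cc4)c3)cn2n1`) at 9230 nM on a different core. Compound 4 (`COc1ncc(-c2ccc3nc(NC(C)=O)nn3c2)cc1NS(=O)(=O)c1ccc(F)cc1F`) differs from compound 3 by 2,4-difluorophenyl in place of 4-chlorophenyl on a sulfonyl sulfur and keeps its core. For the measured compounds named here, only one measured step bears on this group: a 3.5-fold lower number from compound 1 to compound 2 (0.54 log units; beyond the scatter) with methyl in place of fluoro on an aromatic carbon. Going by the values given here, that modest step leaves the fluoro member higher, but no measured pair tests this exact exchange. Expected in this assay is a 1.4-fold higher number from compound 3 to compound 4 (0.13 log units; within the scatter) and thus no shift beyond the scatter, with any drift toward a higher number. Compound 4 is estimated at 1000 nM with an expected range from 250 nM to 4000 nM in this estimate.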

Compound 4, half-maximal inhibitory concentration: 740 nM
Estimate against measurement, compound 4: 1.4-fold (0.13 log units) above; measured number inside the range.
By their numbers in this assay, from the lowest: compounds 3 and 4 (each within the scatter of the next); then compound 2; then compound 1.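

On the shared core, this assay does not separate 2,4-difluorophenyl from 4-chlorophenyl on a sulfonyl sulfur, with no change at the digits printed from compound 3 to compound 4 (within the scatter) as the step. For the compounds shown here, the aryl group at this position therefore tolerates this exchange of halogen pattern, and the higher number carried by the fluoro member in a 3.5-fold lower number from compound 1 to compound 2 (0.54 log units; beyond the scatter) on the core of compound 1 finds no counterpart here.

Left open is whether an amine or a carboxylic acid on this aryl ring, or a longer chain in its place, would move the number beyond the scatter. Nothing on hand offers an explanation for the match between these two groups.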